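The source may hold more compounds than are shown below. What is called first, only, known or untested is meant among the compounds shown, and "the series" means these compounds.

Measured in an ADME assay on THP-1 cells (Homo sapiens) for cytotoxicity; a higher number here means a weaker inhibitor, a lower number a stronger inhibitor:
compound 1 `COc1ccccc1-c1nnc(-c2ccc(C(=O)N/N=C/c3ccccn3)cc2)o1` gives 67000 nM
compound 2 `COc1ccc(/C=N/NC(=O)c2ccc(-c3nnc(-c4ccccc4OC)o3)cc2)cc1O` gives 260000 nM
compound 3 `COc1ccc(/C=N/NC(=O)c2ccc(-c3nnc(-c4ccccc4OC)o3)cc2)c(O)c1` gives 308000 nM

Compound 2 stands second highest of the three numbers. Its nearest neighbour: a 1.2-fold higher number from compound 2 to compound 3 (0.07 log units; within the scatter). Its furthest: a 3.9-fold higher number from compound 1 to compound 2 (0.59 log units; beyond the scatter).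

Compound 4 `COc1ccccc1-c1nnc(-c2ccc(C(=O)N/N=C/c3ccc(O)cc3)cc2)o1` differs from compound 2 by 4-hydroxyphenyl in place of 3-hydroxy-4-methoxyphenyl on a carbon with a double bond to nitrogen. Among the measured compounds shown here, no measured step exchanges these two groups directly. The steps that touch this position are a 3.9-fold higher number from compound 1 to compound 2 (0.59 log units; beyond the scatter) and a 4.6-fold higher number from compound 1 to compound 3 (0.66 log units; beyond the scatter), both modest, while a 1.2-fold higher number from compound 2 to compound 3 (0.07 log units; within the scatter) shows that shifting the hydroxyl within the same ring stays within the scatter. Since 4-hydroxyphenyl is again a hydroxyl-bearing ring at the same place, a step within the scatter, leaning slightly toward a lower number, is expected: a 1.3-fold lower number from compound 2 to compound 4 (0.11 log units; within the scatter). Compound 4 is estimated at 200000 nM, range 100000 nM to 400000 nM.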

Compound 4, half-maximal inhibitory concentration: 261000 nM
For compound 4 the middle estimate is 1.3-fold (0.12 log units) below the measured one; the measured number falls inside the stated range.
By their numbers in this assay, from the lowest: compound 1; then compounds 2, 4 and 3 (each within the scatter of the next).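

In this assay, 4-hydroxyphenyl in place of either hydroxy-methoxyphenyl group on the carbon with a double bond to nitrogen stays within the scatter (for the 3-hydroxy-4-methoxyphenyl group, a 1.0-fold higher number from compound 2 to compound 4 (0.00 log units; within the scatter); for the 2-hydroxy-4-methoxyphenyl group, a 1.2-fold lower number from compound 3 to compound 4 (0.07 log units; within the scatter)), so the methoxy group shows no measurable contribution among these rings. The separation from pyridin-2-yl holds for a third hydroxyl-bearing ring (a 3.9-fold higher number from compound 1 to compound 4 (0.59 log units; beyond the scatter)). No available evidence explains this separation.

Still open, from the compounds shown here alone, is whether a plain phenyl, or a phenyl carrying an amine or a carboxylic acid, at this place would group with compound 1 or with compounds 2, 3 and 4.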